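Para substituent on compound 2: bromo exchanged for cyano

The source may hold more compounds than are shown below. What is called first, only, known or untested is meant among the compounds shown, and "the series" means these compounds.

Among the measured compounds shown here, in a functional assay on the whole organism (integument) for inhibition, with Chilo suppressalis as the target, read by scintillation counting, with a stated time of 72 h (on this read-out lower numbers stand for stronger inhibition and higher numbers for weaker inhibition), compound 2 `COc1cccc(OC)c1C(=O)Nc1nnc(-c2ccc(Br)cc2)s1` gives 66.1 nM, the lowest of the two numbers measured so far; compound 1 `COc1cccc(OC)c1C(=O)Nc1nnc(-c2ccc(C)cc2)s1` gives 1230 nM. For the measured compounds named here, the one measured step is a 19-fold lower number from compound 1 to compound 2 (1.27 log units; beyond the scatter), a large one. Compound 3 `COc1cccc(OC)c1C(=O)Nc1nnc(-c2ccc(C#N)cc2)s1` differs from compound 2 by cyano in place of bromo on an aromatic carbon. Going by the values given here, that measured step bears on the new change only loosely: it shows the number responds strongly to the group at this position, but neither bromo nor methyl indicates what cyano will do, and the 1 hydrogen-bond acceptor that enters has no counterpart among the measured compounds. A moderate rise in the number for compound 3 is therefore expected, one that falls well short of undoing a 19-fold lower number from compound 1 to compound 2 (1.27 log units; beyond the scatter). The expected step is a 2.3-fold higher number from compound 2 to compound 3 (0.36 log units; beyond the scatter). Compound 3 is estimated at 150 nM, with a range from 40 nM to 600 nM.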

Compound 3, half-maximal inhibitory concentration: 209 nM
The estimate for compound 3 lay 1.4-fold (0.14 log units) below the measured number, within the range that was stated.
By their numbers in this assay, from the lowest: compound 2; then compound 3; then compound 1.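

In this assay the change from 4-bromophenyl to 4-cyanophenyl gives a 3.2-fold higher number from compound 2 to compound 3 (0.50 log units; beyond the scatter) and so gives up part of the advantage of bromo, while cyano in place of methyl still gives a 5.9-fold lower number from compound 1 to compound 3 (0.77 log units; beyond the scatter) and the group at this place therefore does more than separate bromo from everything else. With three groups on the same aromatic carbon, the numbers now run from bromo through cyano to methyl, and each gap lies beyond the scatter. No measurement at hand accounts for this order.

From the compounds shown here alone, whether a chloro, an amine, a carboxylic acid or a longer chain at this place would fall inside or outside this order remains open. Also open, going by these compounds, is whether the same order would hold with a different group on the dimethoxybenzoyl side of the shared core.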